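Working notes: isopropyl in place of methyl on compound 2

The source may report more compounds than this note shows. Statements on the series, on what has been measured and on what is new or still open speak of the compounds shown alone.

Compound 1 `Cc1cc(Cl)cc(C)c1NC(=O)[C@H](C)N`: 25.5 mg/kg
Compound 2 `Cc1cc(Cl)ccc1NC(=O)[C@H](C)N`: 41.3 mg/kg
Compound 3 `Cc1cccc(C)c1NC(=O)[C@H](N)C(C)C`: 5.7 mg/kg

All three values come from a functional assay on the whole organism (strain Swiss Albino) with Mus musculus as the target; on this read-out lower numbers stand for an effect already at smaller amounts and higher numbers for an effect only at larger amounts of compound. Compound 2 stands at the upper end of these numbers, within the scatter of compound 1, while compound 3 lies clearly lower.

The next compound is compound 4 `Cc1cc(Cl)ccc1NC(=O)[C@@H](N)C(C)C`, reached from compound 2 by isopropyl in place of methyl on a saturated chain carbon bound to an amine nitrogen and a carbonyl carbon. Within the data shown here, the only measured step, a 1.6-fold higher number from compound 1 to compound 2 (0.21 log units; within the scatter), lies within the scatter and concerns another place, so it gives no direct size for this change. Compound 3 also carries isopropyl, on a differently substituted core, and its 5.7 mg/kg points towards a lower number. A moderate move downwards is therefore expected in this assay. The estimate is a 2.3-fold lower number from compound 2 to compound 4 (0.36 log units; beyond the scatter). For compound 4 the expected value is 18 mg/kg, with an estimated range of 7 mg/kg to 45 mg/kg.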

Compound 4, dose for half-maximal effect: 25.9 mg/kg
The estimate for compound 4 lay 1.4-fold (0.16 log units) below the measured number; low and high end bracket the measured number.
By their numbers in this assay, from the lowest: compound 3; then compounds 1, 4 and 2 (each within the scatter of the next).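

This position now has a direct reading: in this assay, isopropyl in place of methyl on the saturated chain carbon bound to an amine nitrogen and a carbonyl carbon gives a 1.6-fold lower number from compound 2 to compound 4 (0.20 log units; within the scatter). On the core of compound 2, this change therefore produces no step beyond the scatter. No measured evidence available here bears on the size of this step.

Still open, on these data alone, is whether a longer chain, a phenyl group or a hydroxymethyl group at this carbon would move the number beyond the scatter. As far as these compounds go, the same isopropyl change on the core of compound 1 also remains open.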